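This account rests on a few compounds, and the source may have more. Where it says the series, first, only, none or still open, it means among the compounds named here.

In an ADME assay on HeLa cells (Homo sapiens) for cytotoxicity, read by MTT assay (on this read-out higher numbers stand for weaker inhibition and lower numbers for stronger inhibition), compound 1, `COC(=O)[C@@H](NC(=O)CCC(=O)Oc1ccc(C[C@H]2C(=O)OC[C@@H]2Cc2ccc(OC)c(OC)c2)cc1OC)c1c[nH]c2ccccc12`, reaches only a limit of the assay, >= 600000 nM. Compound 2, `COc1ccc(C[C@H]2COC(=O)[C@@H]2Cc2ccc(OC(=O)CCC(=O)N3CCCC3)c(OC)c2)cc1OC`, gives 201000 nM in this assay. Compound 3, `COc1ccc(C[C@H]2COC(=O)[C@@H]2Cc2ccc(OCc3cn(Cc4ccccc4F)nn3)c(OC)c2)cc1OC`, likewise stops at a limit of the assay, >= 600000 nM, so no number is known for it. Compound 3 thus stands at the limit of >= 600000 nM in this assay, at which 2 of the 3 values shown sit. The unmeasured compound 4 is `COc1ccc(C[C@H]2COC(=O)[C@@H]2Cc2ccc(OCc3cn(Cc4ccc(Cl)cc4)nn3)c(OC)c2)cc1OC`, and it differs from compound 3 by 4-chlorophenyl in place of 2-fluorophenyl on a saturated chain carbon bound to an aromatic nitrogen. For the measured compounds named here, no step between measured compounds is available here, so the shift from compound 3 to compound 4 in this assay is expected to be none beyond the scatter, a number no higher from compound 3 to compound 4 (the limit leaves the size open). Compound 4 is therefore expected to sit again at the limit, estimated at 600000 nM, between 250000 nM and 1200000 nM.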

Compound 4, half-maximal inhibitory concentration: 242000 nM
Compound 4: the middle estimate sits 2.5-fold (0.39 log units) above what was measured; the measured number lies below the stated range.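

At this place, on a saturated chain carbon bound to an aromatic nitrogen, the aryl group affects the read-out in this assay: 4-chlorophenyl in place of 2-fluorophenyl gives an at least 2.4-fold lower number from compound 3 to compound 4 (0.39 log units; beyond the scatter). For the compounds shown here, compound 4 thus gives a number where the earlier compounds offered no single-change comparison. The full size of the step stays open, since compound 3 remains at a limit: the limit of >= 600000 nM in this assay, at which 2 of the 4 values shown sit.

Still open, going by these compounds, is whether the halogen or its place on the ring carries the step, which 4-fluorophenyl or 2-chlorophenyl would separate. On these data alone, how a pyridyl ring or a carboxylic acid on the phenyl ring would read is also open.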